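The source may hold more compounds than are shown below. What is called first, only, known or untested is meant among the compounds shown, and "the series" means these compounds.

Series notes. Compound 3 `COc1cc(C(=O)N2CCC(O)C(C)C2)cc2nc(NCc3cc(Cl)ccc3O)oc12` gives 170 nM in an assay on isolated protein for inhibition of thyroid hormone receptor beta (Homo sapiens), read by fluorescence, with a stated time of 30 min (a lower number here means a stronger inhibitor, a higher number a weaker inhibitor), the second highest of the three numbers. Compound 2 `COc1cc(C(=O)N2CCC(O)C(C)C2)cc2nc(NCc3cc(Cl)ccn3)oc12` gives 190 nM, with a 1.1-fold lower number from compound 2 to compound 3 (0.05 log units; within the scatter); compound 1 `COc1cc(C(=O)N2CCC(O)C(C)C2)cc2nc(NCc3cccc(Cl)c3)oc12` gives 25 nM, with a 6.8-fold higher number from compound 1 to compound 3 (0.83 log units; beyond the scatter). Compound 4 `COc1cc(C(=O)N2CCC(O)C(C)C2)cc2nc(NC3(c4cccc(Cl)c4)CC3)oc12` carries 1-(3-chlorophenyl)cyclopropyl in place of 5-chloro-2-hydroxybenzyl on a nitrogen on an aromatic ring. Going by the values given here, two measured steps bear on this: a 6.8-fold higher number from compound 1 to compound 3 (0.83 log units; beyond the scatter) covers the hydroxy, which compound 4 loses again, and a 7.6-fold higher number from compound 1 to compound 2 (0.88 log units; beyond the scatter) covers a change of the ring carrying the chlorine, which compound 4 keeps as in compound 1. Among the compounds with values here, the cyclopropyl on the carbon bound to the nitrogen has no measured precedent in this set, so the estimate is wider. Compound 4 is expected to show a 4.3-fold lower number from compound 3 to compound 4 (0.63 log units; beyond the scatter), a step down beyond the scatter. Compound 4 is estimated at 40 nM, range 12 nM to 150 nM.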

Compound 4, half-maximal inhibitory concentration: 120 nM
Beside the measured number, compound 4's estimate is 3.0-fold (0.48 log units) below it, within the range that was stated.
By their numbers in this assay, from the lowest: compound 1; then compounds 4, 3 and 2 (each within the scatter of the next).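

At this place, on a nitrogen on an aromatic ring, 1-(3-chlorophenyl)cyclopropyl keeps the 3-chlorophenyl ring of compound 1, yet gives a 4.8-fold higher number from compound 1 to compound 4 (0.68 log units; beyond the scatter), so changing the carbon bound to that nitrogen is enough to move the number beyond the scatter. Against the 5-chloro-2-hydroxybenzyl and (4-chloropyridin-2-yl)methyl groups, it does not separate: a 1.4-fold lower number from compound 3 to compound 4 (0.15 log units; within the scatter) and a 1.6-fold lower number from compound 2 to compound 4 (0.20 log units; within the scatter) both lie within the scatter. Nothing measured on these compounds explains the step from the 3-chlorobenzyl group.

Still open, on these data alone, is whether the three-membered ring itself matters, or whether a single methyl on that carbon would give the same number.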